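Hydroxy to carboxy on the core of compound 1

This account rests on a few compounds, and the source may have more. Where it says the series, first, only, none or still open, it means among the compounds named here.

Compound 1 `Cc1c(C(=O)Nc2c(F)cc(-c3cccc(F)c3)cc2F)nc2ccc(F)cc2c1O` gives 0.35% in a functional assay on Hep 3B2 cells (Homo sapiens) for antiproliferative activity, read by MTT assay, with a stated time of 24 h, tested at 0.02 ug/mL (a higher number here means a stronger effect of the compound at the concentration tested, a lower number a weaker effect), the lowest of the two numbers shown. Compound 2 `Cc1c(C(=O)Nc2c(F)cc(-c3cccc(F)c3)cc2F)nc2ccc(OC(F)(F)F)cc2c1O` gives 0.67% in this assay, and the step of a number 0.3 percentage points higher from compound 1 to compound 2 (within the scatter) stays within the scatter. Compound 3 `Cc1c(C(=O)Nc2c(F)cc(-c3cccc(F)c3)cc2F)nc2ccc(F)cc2c1C(=O)O` differs from compound 1 by carboxy in place of hydroxy on an aromatic carbon. No measured step touches this place on the core, and the single step shown moved nothing beyond the scatter, so in this assay no step beyond the scatter is expected in either direction. For compound 3 the expected value is 1%, with a range of 0% to 10%. The step of a number 0.7 percentage points higher from compound 1 to compound 3 (within the scatter) is thus expected to remain within the scatter.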

Compound 3, a percentage reported as inhibition, at one concentration (the size of the read-out at that concentration, not a potency): -0.13%
The estimate for compound 3 lay 1.1 percentage points above the measured number; measured number below the stated range.
By their numbers in this assay, from the lowest: compounds 3, 1 and 2 (each within the scatter of the next).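

In this assay, carboxy in place of hydroxy opposite the ring nitrogen gives a number 0.5 percentage points lower from compound 1 to compound 3 (within the scatter) and is the only step shown at this position on the core. This exchange of a larger group for hydroxy, ortho to a methyl group, therefore shows no change beyond the scatter. No evidence on the cause of this result is at hand.

As far as these compounds go, whether an amine or a methoxy group at this position would move the number beyond the scatter remains open. From the compounds shown here alone, all three numbers come from a single concentration, so potency also remains open.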